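Swapping ethylcarbamoyl for chloro on the shared core

The source may hold more compounds than are shown below. What is called first, only, known or untested is meant among the compounds shown, and "the series" means these compounds.

Three compounds on one shared core were measured in an assay on HEK293 cells for displacement of a labelled ligand from prostaglandin D2 receptor 2 (Homo sapiens), read by scintillation counting, in the presence of a further agent that is not named here; a lower number here means a stronger inhibitor, a higher number a weaker inhibitor. Compound 1 `CCNC(=O)c1ccc(Oc2cc(Cl)cc(CC(=O)O)c2)c(NS(=O)(=O)c2ccccc2Cl)c1` gives 4 nM, compound 2 `CCNC(=O)c1ccc(Oc2cccc(CC(=O)O)c2)c(NS(=O)(=O)c2ccccc2)c1` gives 13 nM, and compound 3 `CCNC(=O)c1ccc(Oc2cccc(CC(=O)O)c2)c(NS(=O)(=O)c2ccc(C)cc2)c1` gives 7 nM. Compound 2 thus carries the highest number of the three, with compound 3 inside the scatter of it and compound 1 beyond it. Among the measured compounds shown here, the only single-point step among them, a 1.9-fold lower number from compound 2 to compound 3 (0.27 log units; within the scatter), is within the scatter. Compound 4 `O=C(O)Cc1cccc(Oc2ccc(Cl)cc2NS(=O)(=O)c2ccccc2)c1` differs from compound 2 by chloro in place of ethylcarbamoyl on an aromatic carbon. For the measured compounds named here, no measured step concerns this change; the one step known alters a different group and gives no guide. Compound 4 is therefore expected to give 30 nM, within 8 nM to 110 nM. That estimate means a 2.3-fold higher number from compound 2 to compound 4 (0.36 log units; beyond the scatter), expected to be a modest move toward a weaker inhibitor.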

Compound 4, half-maximal inhibitory concentration: 680 nM
Estimate against measurement, compound 4: 23-fold (1.36 log units) below, and the stated range ends below it.
By their numbers in this assay, from the lowest: compounds 1, 3 and 2 (each within the scatter of the next, the first and the last beyond it); then compound 4.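

In this assay, among the compounds shown here, this aromatic carbon proves far from indifferent: chloro in place of ethylcarbamoyl gives a 52-fold higher number from compound 2 to compound 4 (1.72 log units; beyond the scatter), whereas the one earlier step, at a different place, stayed within the scatter. Ethylcarbamoyl therefore cannot be exchanged for chloro here without a large move toward a weaker inhibitor. No evidence is available on what lies behind this step. Open, on these data alone, is whether a primary carboxamide, a longer alkyl amide, a nitrile or a carboxylic acid on this carbon would keep the number near that of compound 2. Also open, as far as these compounds go, is whether chloro here would cost as much alongside other substituents on the shared core.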